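A Chloro Substituent on a Cytotoxically Silent Scaffold

The compounds below may be only part of what the source reports. "The series", "measured", "known", "first", "only" and "open" are said of these compounds alone.

Compound 1 `Cc1c(-c2csc(NC(=S)Nc3ccccc3)n2)c(=O)n(-c2ccccc2)n1C` in a functional assay on A549 cells (Homo sapiens) for cytotoxicity, read by sulforhodamine B assay, with a stated time of 72 h (a higher number here means a weaker inhibitor, a lower number a stronger inhibitor), gives 7740 nM. Compound 2 `Cc1c(-c2csc(/N=c3\sc(-c4ccccc4)nn3-c3ccccc3)n2)c(=O)n(-c2ccccc2)n1C` in this assay reaches only the limit > 100000 nM. Compound 3 `CC(=O)c1nn(-c2ccccc2)/c(=N/c2nc(-c3c(C)n(C)n(-c4ccccc4)c3=O)cs2)s1` in this assay likewise sits at the limit > 100000 nM. The step that the two limits leave unreadable from compound 2 to compound 3 thus cannot be read, since both ends rest at the limit of > 100000 nM in this assay, at which 2 of the 3 values shown sit. Compound 4 `CC(=O)c1nn(-c2ccc(Cl)cc2)/c(=N/c2nc(-c3c(C)n(C)n(-c4ccccc4)c3=O)cs2)s1` differs from compound 3 by chloro in place of hydrogen on an aromatic carbon, para to a large group on the phenyl ring. Within the data shown here, no measured step touches this position, so the only guide is that compound 3 stands at a limit and that its close relative compound 2 does too. Compound 4 is therefore expected to stay near that limit in this assay, with a step of a number no higher from compound 3 to compound 4 (the limit leaves the size open) amounting to little. The estimate for compound 4 is 100000 nM, between 30000 nM and 300000 nM.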

Compound 4, half-maximal inhibitory concentration: > 100000 nM
Compound 4: no number, only a limit; the forecaster's own chance of this, stated with the estimate: 80%; the middle value lies on the limit itself.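

Among these compounds, compound 3 and compound 4 both rest at a limit in this assay, so no step between them can be read: the limit of > 100000 nM in this assay, at which 3 of the 4 values shown sit. From the compounds shown here alone, whether chloro in place of hydrogen changes cytotoxicity at all remains open.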